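From cyano to 4-methylpiperazin-1-yl on compound 2

A few compounds are considered here, and "the series" means these few. Any claim that something is new, unique, unknown or untested is made for them only; others in the source may bear on it.

- Compound 1 `FC(F)(F)c1cccc(-c2nc3cnc(Nc4ccncn4)cc3[nH]2)c1`: 200000 nM
- Compound 2 `N#Cc1ccc(Nc2cc3[nH]c(-c4cccc(C(F)(F)F)c4)nc3cn2)nc1`: < 5000 nM (a limit)
- Compound 3 `O=C(O)c1ccnc(Nc2cc3[nH]c(-c4cccc(C(F)(F)F)c4)nc3cn2)c1`: < 5000 nM (a limit)

In a physicochemical assay for solubility, using the shake flask method, measured as kinetic solubility, with a stated time of 20 h, at pH 2 (a higher number here means a more soluble compound, a lower number a less soluble compound), compound 2 gives < 5000 nM as a limit and not a number. Compound 4 `CN1CCN(c2ccc(Nc3cc4[nH]c(-c5cccc(C(F)(F)F)c5)nc4cn3)nc2)CC1` differs from compound 2 in one place, with 4-methylpiperazin-1-yl in place of cyano on an aromatic carbon and the rest unchanged.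

For the measured compounds named here, no measured step makes this exact change. The nearest ones alter the group on a nitrogen on an aromatic ring, and they show an at least 40-fold lower number from compound 1 to compound 2 (1.60 log units; beyond the scatter) and also an at least 40-fold lower number from compound 1 to compound 3 (1.60 log units; beyond the scatter) as large steps. The remaining one is a step that the two limits leave unreadable from compound 2 to compound 3 and adds nothing here. Compound 1 with 200000 nM shows that the shared core can reach high numbers in this assay and so a large rise is expected. The expected step is an at least 8.0-fold higher number from compound 2 to compound 4 (0.90 log units; beyond the scatter) and it remains uncertain. For compound 4 the estimate is 40000 nM with an expected range from 5000 nM to 200000 nM as a rough guide.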

Compound 4, solubility: 190000 nM
Estimate against measurement, compound 4: 4.8-fold (0.68 log units) below; the range from low to high includes it.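

The earlier steps shown here swapped the whole group on the nitrogen, whereas this one changes only the group on an aromatic carbon of the six-membered aromatic ring with 1 nitrogen, two atoms from the ring nitrogen. In this assay, replacing cyano with 4-methylpiperazin-1-yl there gives an at least 38-fold higher number from compound 2 to compound 4 (1.57 log units; beyond the scatter), so one change at this position, with the rest of the molecule the same, is enough to lift the read-out clear of a limit, whereas the earlier readable steps both ran downward. Compound 2 gives a limit and not a number: the limit of < 5000 nM in this assay, at which 2 of the 4 values shown sit.

Still open, going by these compounds, is whether the whole 4-methylpiperazin-1-yl group is needed, or whether a simple amine such as dimethylamino at this position would give a similar number. A carboxylic acid at this same position also remains an open case.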